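The source may report more compounds than this note shows. Statements on the series, on what has been measured and on what is new or still open speak of the compounds shown alone.

Values in an ADME assay on MDCK cells (Canis lupus familiaris) for cytotoxicity, read by MTT assay, with a stated time of 48 h; a higher number here means that more compound is tolerated, a lower number that less compound is tolerated
- compound 1 `COc1ccc(-c2cn(CC3=C(Cl)c4ccc(-c5cccs5)nc4CC3)nn2)cc1` gives > 300 ug/mL (a limit of the assay)
- compound 2 `Fc1ccc(-c2cn(CC3=C(Cl)c4ccc(-c5cccs5)nc4CC3)nn2)cc1` gives 100 ug/mL
- compound 3 `Fc1ccc(-c2cn(CC3=C(Cl)c4ccc(-c5cccs5)nc4CC3)nn2)c(F)c1` gives 188 ug/mL

Compound 3 stands close to compound 2. The measured gap is a 1.9-fold higher number from compound 2 to compound 3 (0.27 log units; within the scatter) and the two cannot be ranked. The next change leads to compound 4 `FC(F)(F)Oc1ccc(-c2cn(CC3=C(Cl)c4ccc(-c5cccs5)nc4CC3)nn2)cc1` and is 4-(trifluoromethoxy)phenyl in place of 2,4-difluorophenyl on an aromatic carbon with 4-(trifluoromethoxy)phenyl in place of 2,4-difluorophenyl on an aromatic carbon of the five-membered aromatic ring with 3 nitrogen.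

Within the data shown here, no measured step brings in this group. The closest guides are an at least 3.0-fold lower number from compound 1 to compound 2 (0.47 log units; beyond the scatter) for fluoro in place of methoxy and an at least 1.5-fold lower number from compound 1 to compound 3 (0.20 log units; that floor lies within the scatter) for 2,4-difluorophenyl in place of 4-methoxyphenyl. The steps from compound 1 give only floors because of the limit of > 300 ug/mL in this assay, at which 1 of the 3 values shown sits, in that compound.

Compound 4 carries both the oxygen seen in compound 1 and the fluorine seen in compound 3, so a number near that of compound 3 (188 ug/mL) is expected. In this assay no step beyond the scatter is expected: the estimated step is a 1.2-fold lower number from compound 3 to compound 4 (0.07 log units; within the scatter) with little weight on its direction. For compound 4 the estimated value is 160 ug/mL with an expected range from 70 ug/mL to 300 ug/mL in this read-out.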

Compound 4, half-maximal cytotoxic concentration: > 300 ug/mL
Compound 4 gave a limit, no number; the forecaster's own chance of this, stated with the estimate: 15%; middle value at least 1.8-fold (0.27 log units) from the limit.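

With the group on an aromatic carbon of the five-membered aromatic ring with 3 nitrogen, trifluoromethoxy in place of fluoro gives an at least 3.0-fold higher number from compound 2 to compound 4 (0.47 log units; beyond the scatter) in this assay and so runs opposite to the earlier change from methoxy to fluoro, which now leaves two oxygen-bearing para-free groups, methoxy and trifluoromethoxy, at the top of the readable range, with compound 2 well short of them. Against the 2,4-difluorophenyl group the result is weaker: the change gives an at least 1.5-fold higher number from compound 3 to compound 4 (0.20 log units; that floor lies within the scatter) and does not separate the two compounds. Compound 4 sits at a limit of the assay, as compound 1 does, and the step between those two cannot be read: the limit of > 300 ug/mL in this assay, at which 2 of the 4 values shown sit.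

As far as these compounds go, the order of compound 1 and compound 4, and how far either lies from compound 3, stays open while both remain limits. Also open, from the compounds shown here alone, is whether the same reading holds when the phenyl ring carries an amine or a carboxylic acid, or when a longer alkoxy chain takes the place of trifluoromethoxy.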